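Nitrogen substituent series: from hexyl to benzyl

This account rests on a few compounds, and the source may have more. Where it says the series, first, only, none or still open, it means among the compounds named here.

The shared core is carried by compound 1 `CCN1CCCC[C@H]1[C@H]1COC(c2ccccc2)(c2ccccc2)O1`, compound 2 `CCCN1CCCC[C@H]1[C@H]1COC(c2ccccc2)(c2ccccc2)O1` and compound 3 `CCCCCCN1CCCC[C@H]1[C@H]1COC(c2ccccc2)(c2ccccc2)O1`. In a functional assay (brain) for displacement of a labelled ligand, with Rattus norvegicus as the target (a lower number here means a stronger inhibitor, a higher number a weaker inhibitor), compound 1 gives 6900 nM, compound 2 gives 6800 nM and compound 3 gives 21200 nM. Compound 3 thus has the highest number of the three, with compound 1 nearest and compound 2 furthest, both at the same distance. The steps of a 1.0-fold lower number from compound 1 to compound 2 (0.01 log units; within the scatter), a 3.1-fold higher number from compound 1 to compound 3 (0.49 log units; beyond the scatter) and a 3.1-fold higher number from compound 2 to compound 3 (0.49 log units; beyond the scatter) show that lengthening the chain to the longest member raises the number, while the shortest lengthening stays within the scatter.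

Compound 4 `c1ccc(CN2CCCC[C@H]2[C@H]2COC(c3ccccc3)(c3ccccc3)O2)cc1` is not yet measured. It differs from compound 3 by phenyl in place of pentyl on a saturated chain carbon bound to an amine nitrogen in a ring; cut one bond further out, the change reads hexyl to benzyl. Within the data shown here, none of the measured steps puts an aromatic ring on this chain, so they bear on the change only in that the chain length stays close to that of compound 3. No step beyond the scatter is therefore expected in this assay, though a slight drift to a lower number is possible. For compound 4 the estimate in this assay is 12000 nM, with a range from 4000 nM to 36000 nM, which is expected to mean a step of a 1.8-fold lower number from compound 3 to compound 4 (0.25 log units; within the scatter).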

Compound 4, inhibition constant: 10100 nM
For compound 4 the middle estimate is 1.2-fold (0.07 log units) above the measured one; measured number inside the range.
By their numbers in this assay, from the lowest: compounds 2, 1 and 4 (each within the scatter of the next); then compound 3.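

Hexyl to benzyl, with phenyl in place of pentyl on a saturated chain carbon bound to an amine nitrogen in a ring, is the first change here that lowers the number beyond the scatter in this assay (a 2.1-fold lower number from compound 3 to compound 4 (0.32 log units; beyond the scatter)). An aromatic ring at this position therefore carries no penalty like the one seen with hexyl, since compound 4 stays within the scatter of both short-chain compounds (a 1.5-fold higher number from compound 2 to compound 4 (0.17 log units; within the scatter); a 1.5-fold higher number from compound 1 to compound 4 (0.17 log units; within the scatter)). Nothing among the data shown explains this step.

On these data alone, it remains open whether the change in number belongs to the aromatic ring itself or only to the loss of the hexyl chain. A cyclohexylmethyl group or a phenylethyl chain at the same place would separate the two, and a pentyl chain would show where along the chain the number starts to rise.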